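Methoxy for Methyl: Expecting a Fourth Compound's Binding

The source may report more compounds than this note shows. Statements on the series, on what has been measured and on what is new or still open speak of the compounds shown alone.

Three compounds were measured in an assay on isolated protein for displacement of a labelled ligand from metabotropic glutamate receptor 5 (Homo sapiens), with a stated time of 60 min, tested at 1 uM; a higher number here means more inhibition at the concentration tested (going by the name of the read-out), a lower number less inhibition. Compound 3 `Cc1ccc2ncc(S(=O)(=O)c3ccc(C)c(Cl)c3)c(N3CCC(C)CC3)c2c1` gives 91%. Compound 1 `COc1ccc2ncc(S(=O)(=O)c3ccc(C)c(Cl)c3)c(N3CCC(C)CC3)c2c1` gives 85% in this assay. The change between them is methoxy in place of methyl on an aromatic carbon and it produced a number 6 percentage points lower from compound 3 to compound 1 (within the scatter). Compound 2 `Cc1ccc2ncc(S(=O)(=O)c3cc(F)cc(F)c3)c(N3CCC(C)CC3)c2c1` gives 72% in this assay, the lowest of the three. Its core differs from the core of compound 3 by 3,5-difluorophenyl in place of 3-chloro-4-methylphenyl on a sulfonyl sulfur, and that change gave a number 19 percentage points higher from compound 2 to compound 3 (beyond the scatter).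

Compound 4 `COc1ccc2ncc(S(=O)(=O)c3cc(F)cc(F)c3)c(N3CCC(C)CC3)c2c1` has not yet been measured. It differs from compound 2 by methoxy in place of methyl on an aromatic carbon, the same change seen between compound 3 and compound 1, at the same place. A step of a number 5 percentage points lower from compound 2 to compound 4 (within the scatter) is expected because the same change gave a number 6 percentage points lower from compound 3 to compound 1 (within the scatter). Compound 4 is therefore estimated at 67%, with a likely range from 55% to 80%.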

Compound 4, a percentage reported as inhibition, at one concentration (the size of the read-out at that concentration, not a potency): 30%
The estimate for compound 4 lay 37 percentage points above the measured number, and the stated range ends above it.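

In this assay, methoxy in place of methyl did not carry over from one core to the other, giving a number 42 percentage points lower from compound 2 to compound 4 (beyond the scatter), and the two steps differ: the same change on two cores in this assay, a number 6 percentage points lower (within the scatter) from compound 3 to compound 1 and a number 42 percentage points lower (beyond the scatter) from compound 2 to compound 4, 36 percentage points apart, beyond the scatter of two such steps. The change on the sulfonyl sulfur also depends on its partner, with 3,5-difluorophenyl in place of 3-chloro-4-methylphenyl giving a number 55 percentage points lower from compound 1 to compound 4 (beyond the scatter): the same change on two cores in this assay, a number 19 percentage points higher (beyond the scatter) from compound 2 to compound 3 and a number 55 percentage points higher (beyond the scatter) from compound 4 to compound 1, 36 percentage points apart, beyond the scatter of two such steps. So, across these four compounds, the effect of each change depends on the other group present, but a single pair of cores cannot show why, or how the methoxy change would behave with any other group on the sulfonyl sulfur.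

Going by these compounds, it remains open whether an ethoxy group or an amine in place of the methyl would follow the same split between the two cores. The same question stands for a monofluorophenyl or an unsubstituted phenyl on the sulfonyl sulfur.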